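The source may hold more compounds than are shown below. What is called first, only, known or untested is meant among the compounds shown, and "the series" means these compounds.

Measured compounds:
Compound 1 `CC(C)(C)C(=O)Nc1ccc(S(=O)(=O)Oc2ccccc2I)cc1` — in a functional assay on HT-29 cells (Homo sapiens) for antiproliferative activity, read by sulforhodamine B assay, with a stated time of 48 h (a lower number here means a stronger inhibitor, a higher number a weaker inhibitor), compound 1 gives 9500 nM.
Compound 2 `O=C(CCCl)Nc1ccc(S(=O)(=O)Oc2ccccc2I)cc1` — in this assay compound 2 gives 14000 nM.

Compound 2 stands at the higher of the two numbers, but the difference from compound 1 is small: the step of a 1.5-fold higher number from compound 1 to compound 2 (0.17 log units; within the scatter) lies within the scatter, so the two compounds are not told apart by these data.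

Compound 3 `O=C(NCCCCl)Nc1ccc(S(=O)(=O)Oc2ccccc2I)cc1` has not yet been measured in this assay. It differs from compound 2 in one place: (3-chloropropyl)amino in place of 2-chloroethyl on a carbonyl carbon. Among the measured compounds shown here, the only measured step that bears on this part of the molecule is a 1.5-fold higher number from compound 1 to compound 2 (0.17 log units; within the scatter), which swaps one group on the same carbonyl carbon and produces no change beyond the scatter. Nothing measured covers an added amide-type nitrogen at that carbon, so the expectation rests on that single step.

On this basis compound 3 is expected to remain close to compound 2, with an estimated step of a 1.1-fold higher number from compound 2 to compound 3 (0.03 log units; within the scatter) in this assay. The estimate for compound 3 is 15000 nM, with a range from 5000 nM to 45000 nM.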

Compound 3, half-maximal inhibitory concentration: 9600 nM
Compound 3: middle estimate off by 1.6-fold (0.19 log units), on the high side, within the range that was stated.
By their numbers in this assay, from the lowest: compounds 1, 3 and 2 (each within the scatter of the next).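

Putting (3-chloropropyl)amino in place of 2-chloroethyl on the carbonyl carbon gives a 1.5-fold lower number from compound 2 to compound 3 (0.16 log units; within the scatter) in this assay, so adding an amide-type nitrogen at that carbon, together with one hydrogen-bond donor, does not separate compound 3 from compound 2. The comparison with tert-butyl gives a 1.0-fold higher number from compound 1 to compound 3 (0.00 log units; within the scatter), which also leaves compound 3 unresolved from compound 1, and the three groups now shown on this carbonyl carbon cannot be told apart in this measurement, although only compound 1 lacks chlorine. Among the compounds shown here, the result therefore extends what was seen with the first two compounds to a group carrying that added nitrogen, but no supporting measurement bears on it, and it offers no explanation.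

The compounds shown leave open whether any group at this position can move the number beyond the scatter, for example a terminal amine, a carboxylic acid, a phenyl ring or a much longer chain. They also leave open whether a (propyl)amino group without its chlorine would read the same as the (3-chloropropyl)amino group of compound 3.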